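Replacing the 4-acetylphenyl group of compound 2

A few compounds are considered here, and "the series" means these few. Any claim that something is new, unique, unknown or untested is made for them only; others in the source may bear on it.

Measured so far in a functional assay on HMEC-1 cells (Homo sapiens) for antiproliferative activity, read by cell counting, with a stated time of 4 days; a lower number here means a stronger inhibitor, a higher number a weaker inhibitor:
Compound 1 `CC(Nc1ccccc1Oc1cccc(F)c1)=C1C(=O)CC(c2ccccc2)CC1=O`: 360 nM
Compound 2 `CC(=O)c1ccc(Oc2ccccc2NC(C)=C2C(=O)CC(c3ccccc3)CC2=O)cc1`: 180 nM
Compound 3 `COc1ccc(Oc2ccccc2NC(C)=C2C(=O)CC(c3ccccc3)CC2=O)cc1`: 83 nM

Compound 2 cannot be told apart from its nearest neighbour, as the numbers show a 2.0-fold lower number from compound 1 to compound 2 (0.30 log units; within the scatter). A clearer gap opens on its other side, where compound 3 holds the lowest number of the three, with a 2.2-fold lower number from compound 2 to compound 3 (0.34 log units; beyond the scatter).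

The next structure is compound 4 `COc1cc(Oc2ccccc2NC(C)=C2C(=O)CC(c3ccccc3)CC2=O)ccc1N`, which puts 4-amino-3-methoxyphenyl in place of 4-acetylphenyl on an oxygen on an aromatic ring.

Going by the values given here, two measured steps bear on this change. Compound 3 also carries a methoxy instead of the acetyl, and that swap gave a 2.2-fold lower number from compound 2 to compound 3 (0.34 log units; beyond the scatter). Compared with the 3-fluorophenyl of compound 1, the 4-methoxyphenyl of compound 3 gave a 4.3-fold lower number from compound 1 to compound 3 (0.64 log units; beyond the scatter). Both steps are modest and point towards lower numbers. However, compound 4 has 4-amino-3-methoxyphenyl rather than 4-methoxyphenyl, and no measured compound carries an amino group, so the data offer only a loose guide.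

A small move in the same direction is therefore expected, namely a 1.8-fold lower number from compound 2 to compound 4 (0.26 log units; within the scatter). Compound 4 is estimated at 100 nM, with an expected range from 30 nM to 300 nM as a deliberately wide allowance.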

Compound 4, half-maximal inhibitory concentration: 29 nM
Estimate against measurement, compound 4: 3.4-fold (0.54 log units) above; the whole stated range lies above it.
By their numbers in this assay, from the lowest: compound 4; then compound 3; then compounds 2 and 1 (each within the scatter of the next).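

In this assay, going by these compounds alone, the ring on this oxygen has more room for improvement than the first three compounds showed: 4-amino-3-methoxyphenyl in place of 4-acetylphenyl gives a 6.2-fold lower number from compound 2 to compound 4 (0.79 log units; beyond the scatter) and is the first group to go clearly past the 4-methoxyphenyl ring, with a 2.9-fold lower number from compound 3 to compound 4 (0.46 log units; beyond the scatter) for that swap. Within the data shown here, measured against the 3-fluorophenyl ring, the change gives a 12-fold lower number from compound 1 to compound 4 (1.09 log units; beyond the scatter) and is the only large step in the set, so compound 4 now stands clearly lowest of the four and the choice of ring at this place spans a much wider range than before. Nothing at hand explains why this ring does so well.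

Compound 4 differs from compound 3 in both the amino group and the place of the methoxy, so the compounds shown cannot say which of the two carries the gain, and a plain 4-aminophenyl or 3-methoxyphenyl ring on the same oxygen would separate them. A 4-dimethylamino-3-methoxyphenyl or 4-acetamido-3-methoxyphenyl ring would further show whether the free amino group itself is needed.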